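Bromoalkanoyl chalcone amides: furan-2-yl for 4-chlorophenyl

The source may report more compounds than this note shows. Statements on the series, on what has been measured and on what is new or still open speak of the compounds shown alone.

In a functional assay on the whole organism (strain albino) for inhibition, with Rattus norvegicus as the target, read by paw edema, with stated times of 30 min and 1 h, at a dose of 100 mg/kg by the oral route (a lower number here means less inhibition, a higher number more inhibition at the dose given (going by the name of the read-out)), compound 2 `CC(Br)C(=O)Nc1ccc(C(=O)/C=C/c2ccc(Cl)cc2)cc1` gives 39%. Compound 1 `O=C(CBr)Nc1ccc(C(=O)/C=C/c2ccco2)cc1` gives 30% in this assay; the two numbers lie within the scatter of each other, so neither is set apart from the other. Compound 3 `CC(Br)C(=O)Nc1ccc(C(=O)/C=C/c2ccco2)cc1` awaits measurement. It differs from compound 2 by furan-2-yl in place of 4-chlorophenyl on a double-bonded chain carbon bound to a double-bonded chain carbon. For the measured compounds named here, no step between measured compounds isolates this change, as compound 1 and compound 2 differ in two places. With both measured numbers close together, the expected step is small, a number 5 percentage points lower from compound 2 to compound 3 (within the scatter), not beyond the scatter. Compound 3 is estimated to give 34%, within 22% to 46%.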

Compound 3, a percentage reported as inhibition, in the whole organism at one dose (the size of the read-out at that dose, not a potency): 30%
For compound 3 the middle estimate is 4 percentage points above the measured one, within the range that was stated.
By their numbers in this assay, from the lowest: compounds 1, 3 and 2 (each within the scatter of the next).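

Furan-2-yl in place of 4-chlorophenyl on a double-bonded chain carbon bound to a double-bonded chain carbon now has its own step, which reads a number 9 percentage points lower from compound 2 to compound 3 (within the scatter) in this assay and leaves the two rings unseparated. Methyl in place of hydrogen on a saturated chain carbon bound to a bromine atom and a carbonyl carbon gives no change at the digits printed from compound 1 to compound 3 (within the scatter) and is likewise not separated at this position. Nothing available explains either step.

Open, going by these compounds, is whether a longer chain in place of that methyl would give a step beyond the scatter. Also open, on these data alone, is whether an amine or a carboxylic acid on the phenyl ring in place of the chlorine would do so.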